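Hydroxyethylsulfonyl for hydroxypiperidinylcarbonyl: solubility outlook

A few compounds are considered here, and "the series" means these few. Any claim that something is new, unique, unknown or untested is made for them only; others in the source may bear on it.

Working notes on the series. Three compounds share one core: compound 1 `CS(=O)(=O)c1cncc(-c2ccc3ncc(-c4cncc(S(C)(=O)=O)c4)n3n2)c1`, compound 2 `CS(=O)(=O)c1ccc(-c2cnc3ccc(-c4cccc(C(=O)N5CCC(O)CC5)c4)nn23)cc1` and compound 3 `NC(=O)c1ccc(-c2cnc3ccc(-c4cccc(S(=O)(=O)C5CC5)c4)nn23)cc1`. In a physicochemical assay for solubility, at pH 6.5 (a lower number here means a less soluble compound, a higher number a more soluble compound), compound 2 gives 178000 nM, the highest of the two numbers recorded. In this assay compound 1 gives 53000 nM, a gap from compound 2 that lies beyond the usual scatter. For compound 3 this assay reports only a limit and not a number, < 5000 nM; this is the limit of < 5000 nM in this assay, at which 1 of the 3 values shown sits.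

Compound 4 `CS(=O)(=O)c1ccc(-c2cnc3ccc(-c4cccc(S(=O)(=O)CCO)c4)nn23)cc1` is not yet measured. It differs from compound 2 in one place: (2-hydroxyethyl)sulfonyl in place of (4-hydroxypiperidin-1-yl)carbonyl on an aromatic carbon. Among the compounds with values here, no measured pair differs in a single place, so the size of such a step cannot be read from the recorded values. Compound 4 is expected near 60000 nM, within a range from 15000 nM to 200000 nM. The expected step of a 3.0-fold lower number from compound 2 to compound 4 (0.47 log units; beyond the scatter) is a moderate decrease, somewhat beyond the scatter.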

Compound 4, solubility: 8600 nM
Beside the measured number, compound 4's estimate is 7.0-fold (0.84 log units) above it; the whole stated range lies above it.
By their numbers in this assay, from the lowest: compound 4; then compound 1; then compound 2. At a limit, below all of these: compound 3.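

Within the data shown here, the first single-place step shows that this aromatic carbon is far from indifferent in this assay: (2-hydroxyethyl)sulfonyl in place of (4-hydroxypiperidin-1-yl)carbonyl gives a 21-fold lower number from compound 2 to compound 4 (1.32 log units; beyond the scatter). This large step comes although both groups carry 1 hydrogen-bond donor, so that count alone does not track it. Nothing recorded bears on its cause.

Going by these compounds, whether the step follows the sulfonyl or the lost ring stays open. A (4-hydroxypiperidin-1-yl)sulfonyl group or a (2-hydroxyethyl)aminocarbonyl group at this place would separate the two.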